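This account rests on a few compounds, and the source may have more. Where it says the series, first, only, none or still open, it means among the compounds named here.

- Compound 1 `CCCCCC[C@@]1(C)SC(=O)C=C1OCC(=O)OCC`: 39.6 ug/mL
- Compound 2 `CCCCCC[C@@]1(C)SC(=O)C=C1OCCCCCl`: 20.8 ug/mL
- Compound 3 `C=CCOC1=CC(=O)S[C@]1(C)CCCCCC`: 9 ug/mL

All three values come from a functional assay on MCF7 cells (Homo sapiens) for inhibition, read by radiometric assay and XTT assay; a lower number here means a stronger inhibitor, a higher number a weaker inhibitor. Compound 3 has the lowest number and is therefore the strongest inhibitor of the three, with both of its comparisons lying beyond the scatter: a 4.4-fold lower number from compound 1 to compound 3 (0.64 log units; beyond the scatter) and a 2.3-fold lower number from compound 2 to compound 3 (0.36 log units; beyond the scatter).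

The next compound, compound 4 `CCCCCC[C@@]1(C)SC(=O)C=C1OCC(=O)NCC(=O)O`, keeps the shared core and changes one group: (carboxymethyl)carbamoyl in place of vinyl on a saturated chain carbon bound to an oxygen on an unsaturated carbon. Here (carboxymethyl)carbamoyl takes the place of vinyl on a saturated chain carbon bound to an oxygen on an unsaturated carbon.

Going by the values given here, all the measured steps involve this same place. The most useful guide is compound 1, whose ethoxycarbonyl, like the entering group, carries a carbonyl there. Its comparison with vinyl is modest: a 4.4-fold lower number from compound 1 to compound 3 (0.64 log units; beyond the scatter). Read in reverse, that step suggests a move away from vinyl toward a carbonyl-bearing group should raise the number by a similar amount or somewhat more. The other change away from ethoxycarbonyl stayed within the scatter: a 1.9-fold lower number from compound 1 to compound 2 (0.28 log units; within the scatter). Among the compounds with values here, no measured compound carries a carbamoyl group, so this guide is loose.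

The expected change is a 5.0-fold higher number from compound 3 to compound 4 (0.70 log units; beyond the scatter). For compound 4 the estimated value is 45 ug/mL, with an expected range of 18 ug/mL to 110 ug/mL.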

Compound 4, half-maximal inhibitory concentration: > 80 ug/mL
Compound 4: no number, only a limit (the forecaster's own chance of this, stated with the estimate: 25%); middle value at least 1.7-fold (0.24 log units) away from the limit.
By their numbers in this assay, from the lowest: compound 3; then compounds 2 and 1 (each within the scatter of the next). At a limit, above all of these: compound 4.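

In this assay, compound 4 gives no number, only a limit: the limit of > 80 ug/mL in this assay, at which 1 of the 4 values shown sits. Placing (carboxymethyl)carbamoyl on a saturated chain carbon bound to an oxygen on an unsaturated carbon therefore gives the first result in this set that is a limit, and it clearly weakens inhibition relative to the two smaller groups, with an at least 8.8-fold higher number from compound 3 to compound 4 (0.94 log units; beyond the scatter) and an at least 3.8-fold higher number from compound 2 to compound 4 (0.58 log units; beyond the scatter). The comparison with the ethoxycarbonyl ester, where (carboxymethyl)amino replaces ethoxy on a carbonyl carbon, is less firm: with an at least 2.0-fold higher number from compound 1 to compound 4 (0.30 log units; that floor lies within the scatter), the true gap may be larger, but this floor alone does not establish a difference beyond the scatter.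

The entering group combines an amide with a carboxylic acid, so the compounds shown cannot say which part goes with the weaker inhibition. A simple ethylcarbamoyl group and a free carboxylic acid on that same chain carbon would help to separate the two, while a primary amine at the end of the chain would show whether other groups carrying a nitrogen behave the same way.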